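The compounds below may be only part of what the source reports. "The series", "measured", "known", "first", "only" and "open" are said of these compounds alone.

Compound 1: `COC(=O)[C@@]1(C)CCC=C2[C@@H]1CC[C@@H](C)[C@]2(C)Cc1c[nH]c2ccccc12` — in a functional assay on T47D cells (Homo sapiens) for inhibition, read by sulforhodamine B assay, with a stated time of 48 h (on this read-out higher numbers stand for weaker inhibition of growth and lower numbers for stronger inhibition of growth), compound 1 gives 4200 nM.
Compound 2: `COC(=O)[C@@]1(C)CCC=C2[C@@H]1CC[C@@H](C)[C@]2(C)Cc1c[nH]c2c(C)cccc12` — in this assay compound 2 gives 18000 nM.
Compound 3: `COC(=O)[C@@]1(C)CC[C@@H]2C3=C1CC[C@@H](C)[C@]3(C)Cc1c2[nH]c2ccccc12` — in this assay compound 3 gives 3400 nM.

Compound 1 and compound 2 share the same core and differ in a single place: methyl in place of hydrogen on an aromatic carbon. That change produced a 4.3-fold higher number from compound 1 to compound 2 (0.63 log units; beyond the scatter), so the added methyl weakened growth inhibition here. Compound 3 is built on a different core; the difference between the two cores is not broken down here. The values of compound 3 and compound 1 lie within the usual scatter of each other, while compound 2 gives a number well above that of compound 3, beyond the scatter.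

Compound 4, `COC(=O)[C@@]1(C)CC[C@@H]2C3=C1CC[C@@H](C)[C@]3(C)Cc1c2[nH]c2ccc(C)cc12`, has not yet been measured. It differs from compound 3 in one place: methyl in place of hydrogen on an aromatic carbon. Among the measured compounds shown here, this is the same kind of change as the one from compound 1 to compound 2, but not the same: in compound 2 the methyl sits in a system of two rings, ortho to a fused ring and meta to a fused ring, whereas in compound 4 it sits in a system of five rings, meta to a fused ring and para to a fused ring. Because the same kind of change earlier gave a 4.3-fold higher number from compound 1 to compound 2 (0.63 log units; beyond the scatter), the expected step is estimated as a 2.5-fold higher number from compound 3 to compound 4 (0.40 log units; beyond the scatter), tempered by the different surroundings of the methyl. For compound 4 the estimate in this assay is 8500 nM, expected to fall between 3400 nM and 25000 nM.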

Compound 4, concentration for 50% growth inhibition: 16000 nM
Compound 4: the middle estimate sits 1.9-fold (0.27 log units) below what was measured; measured number inside the range.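

In this assay, placing a methyl in place of hydrogen on an aromatic carbon of the five-ring system gives a 4.7-fold higher number from compound 3 to compound 4 (0.67 log units; beyond the scatter), so growth inhibition weakens here, as it did when the same kind of change was made on the core of compound 1. Set side by side, the two steps match in size: the same change on two cores in this assay, a 4.3-fold higher number (0.63 log units; beyond the scatter) from compound 1 to compound 2 and a 4.7-fold higher number (0.67 log units; beyond the scatter) from compound 3 to compound 4, 1.1-fold (0.04 log units) apart, within the scatter of two such steps. Within this series, the weakening from this kind of change therefore carried over from one core to the other, but two pairs do not show that it would hold on further cores, and because the core and the surroundings of the methyl differ together between the pairs, they cannot show how much each contributes or why the methyl weakens growth inhibition.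

The compounds shown leave open whether a methyl at the matching place on each core would give the same step, and whether a fluorine, a methoxy group or a longer chain such as ethyl on the aromatic ring would follow the methyl. Also open, going by these compounds, is how either core would respond if a carboxylic acid or an amide stood in place of the methyl ester.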